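This account rests on a few compounds, and the source may have more. Where it says the series, first, only, none or still open, it means among the compounds named here.

Working notes on the series in a functional assay on PC-3 cells (Homo sapiens) for inhibition; a lower number here means a stronger inhibitor, a higher number a weaker inhibitor. Two compounds have numbers. Compound 1 `Cc1c(C(=O)N/N=C\c2cc(O)ccc2O)oc2cccc(O)c12` gives 95500 nM. Compound 2 `COc1ccccc1/C=N\NC(=O)c1oc2cccc(O)c2c1C` gives 32700 nM. Within the data shown here, compound 2 therefore stands lowest of the two, and its only neighbour is compound 1, separated by a 2.9-fold lower number from compound 1 to compound 2 (0.47 log units; beyond the scatter) through 2-methoxyphenyl in place of 2,5-dihydroxyphenyl on a carbon with a double bond to nitrogen.

Compound 3 `Cc1c(C(=O)N/N=C\c2ccccn2)oc2cccc(O)c12` is not yet measured. Its difference from compound 2 is pyridin-2-yl in place of 2-methoxyphenyl on a carbon with a double bond to nitrogen. Among the measured compounds shown here, the one measured step at this position, a 2.9-fold lower number from compound 1 to compound 2 (0.47 log units; beyond the scatter), shows that the group on this carbon can shift the number beyond the scatter, but it does not involve pyridin-2-yl, and no measured pair shows what removing the methoxy group does. The expectation is therefore kept close to compound 2: the estimated step is a 1.4-fold higher number from compound 2 to compound 3 (0.14 log units; within the scatter), with a slight lean toward a higher number and a wide range either side. Compound 3 is expected to give 45000 nM in this assay, most likely between 12000 nM and 150000 nM.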

Compound 3, half-maximal inhibitory concentration: >= 40000 nM
Compound 3 ended at the assay's limit; the forecaster's own chance of this, stated with the estimate: 15%; the middle value is on the limit's open side.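

In this assay compound 3 gives >= 40000 nM, which is a limit of the assay and not a number: the limit of >= 40000 nM in this assay, at which 1 of the 3 values shown sits. Going by these compounds, at this position, on a carbon with a double bond to nitrogen, the change from 2-methoxyphenyl to pyridin-2-yl yields only a floor, an at least 1.2-fold higher number from compound 2 to compound 3 (0.08 log units; that floor lies within the scatter), so it remains unknown whether this change moves the number beyond the scatter, although the series now includes a six-membered aromatic ring with a hetero atom at this place and that compound gives no number inside the assay's range. The step between compound 1 and compound 3 cannot be read, so pyridin-2-yl and 2,5-dihydroxyphenyl cannot be ordered, and the step from compound 1 to compound 2 remains the only size at this position that is fully readable.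

The compounds shown leave open whether a plain phenyl, or a phenyl ring carrying an amine or a carboxylic acid, on this carbon would give a number clear of the limit. On these data alone, the shared core is the same in all three compounds, so the effect of changing it, for example a longer chain in place of its methyl group, also remains open.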